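Allyl for ethyl on the shared core of compound 2

The compounds below may be only part of what the source reports. "The series", "measured", "known", "first", "only" and "open" are said of these compounds alone.

Compound 1 `CCn1c(SCC(=O)Nc2ccc(/C(C)=N/O)cc2)nnc1-c1ccc(OC)c(OC)c1` gives 75% in a functional assay on the whole organism (strain albino) for inhibition, with Rattus norvegicus as the target, read by paw edema, with stated times of 30 min and 4 h, at a dose of 0.28 mmol/kg by the oral route; a higher number here means more inhibition at the dose given (going by the name of the read-out), a lower number less inhibition. Compound 2 `CCn1c(SCC(=O)Nc2ccc(/C(C)=N/O)cc2)nnc1-c1cc(OC)c(OC)c(OC)c1` gives 70% in this assay, and compound 3 `CCn1c(SCC(=O)Nc2ccc(C(C)=O)cc2)nnc1-c1cc(OC)c(OC)c(OC)c1` gives 68%. The two measured steps are small: a number 5 percentage points lower from compound 1 to compound 2 (within the scatter) and a number 2 percentage points lower from compound 2 to compound 3 (within the scatter). Compound 2 therefore lies within the scatter of both compound 1 and compound 3, so no ranking among the three can be drawn.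

Compound 4 `C=CCn1c(SCC(=O)Nc2ccc(/C(C)=N/O)cc2)nnc1-c1cc(OC)c(OC)c(OC)c1` differs from compound 2 in one place: vinyl in place of methyl on a saturated chain carbon bound to an aromatic nitrogen. Neither measured step touches the chain on the aromatic nitrogen; both concern the other end of the molecule, and both stayed within the scatter. Among the compounds with values here, there is no measured pair that tells how a change at this position moves the read-out, so the expectation rests on the flatness seen so far. Compound 4 is expected to give 68% in this assay, with a likely range from 55% to 80%. The expected step is a number 2 percentage points lower from compound 2 to compound 4 (within the scatter), that is, no move beyond the scatter.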

Compound 4, a percentage reported as inhibition, in the whole organism at one dose (the size of the read-out at that dose, not a potency): 72%
Compound 4: the middle estimate sits 4 percentage points below what was measured; measured number inside the range.
By their numbers in this assay, from the lowest: compounds 3, 2, 4 and 1 (each within the scatter of the next).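

Vinyl in place of methyl on a saturated chain carbon bound to an aromatic nitrogen, the change from ethyl to allyl, gives the only measured step at this position, and this assay records a number 2 percentage points higher from compound 2 to compound 4 (within the scatter) for it. Within the data shown here, the earlier steps concerned the other end of the molecule, so this is the first sign that the chain on the aromatic nitrogen can also change without moving the read-out beyond the scatter. Nothing shown explains why this change leaves the read-out within the scatter.

This single step does not show whether the same holds for a longer chain such as butyl, for a benzyl group or for a chain carrying an amine. It also leaves open whether allyl behaves the same way on the core of compound 1 or compound 3.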